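Aryl group changes on the ring amine nitrogen

A few compounds are considered here, and "the series" means these few. Any claim that something is new, unique, unknown or untested is made for them only; others in the source may bear on it.

Three analogues sharing one core differ only in the aryl group on an amine nitrogen in a ring. Compound 1 `Nc1scc(CN2CCN(c3cccc(Cl)c3Cl)CC2)c1C(=O)c1ccc(Cl)cc1` carries 2,3-dichlorophenyl, and in an assay on CHO cells for displacement of a labelled ligand from adenosine receptor A3 (Homo sapiens), read by scintillation counting, with a stated time of 120 min, tested at 10 uM (on this read-out lower numbers stand for less inhibition and higher numbers for more inhibition at the one concentration tested (going by the name of the read-out)), compound 1 gives 0%. Compound 2 `Nc1scc(CN2CCN(c3ccc([N+](=O)[O-])cc3)CC2)c1C(=O)c1ccc(Cl)cc1` carries 4-nitrophenyl, and in this assay compound 2 gives 2%. Compound 3 `Nc1scc(CN2CCN(c3cc(F)cc(F)c3)CC2)c1C(=O)c1ccc(Cl)cc1` carries 3,5-difluorophenyl, and in this assay compound 3 gives 2%. Going by the values given here, all three numbers sit close together: a number 2 percentage points higher from compound 1 to compound 2 (within the scatter), a number 2 percentage points higher from compound 1 to compound 3 (within the scatter) and no change at the digits printed from compound 2 to compound 3 (within the scatter) are each within the scatter, so compound 3 stands level with compound 2 and no compound in the set can be set apart from the others.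

Compound 4 `Nc1scc(CN2CCN(c3cc(Cl)ccc3Cl)CC2)c1C(=O)c1ccc(Cl)cc1` is the next member. Relative to compound 3 the change is 2,5-dichlorophenyl in place of 3,5-difluorophenyl on an amine nitrogen in a ring. The steps measured so far all swap one aryl group for another in the same place, and none of them moves the read-out beyond the scatter. Two dichlorophenyl patterns are now in the set, on compound 1 and on compound 4, but nothing measured separates the two. The step of a number 1 percentage points lower from compound 3 to compound 4 (within the scatter) is therefore expected to be nothing beyond the scatter. Compound 4 is estimated at 1%, with a range from -6% to 9%.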

Compound 4, a percentage reported as inhibition, at one concentration (the size of the read-out at that concentration, not a potency): 1%
Estimate against measurement, compound 4: no gap at the digits printed; measured number inside the range.
By their numbers in this assay, from the lowest: compounds 1, 4, 2 and 3 (each within the scatter of the next).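

Taken in this assay, 2,5-dichlorophenyl in place of 3,5-difluorophenyl gives a number 1 percentage points lower from compound 3 to compound 4 (within the scatter), and the same group in place of 4-nitrophenyl gives a number 1 percentage points lower from compound 2 to compound 4 (within the scatter), so neither a change of halogen pattern nor the loss of the nitro group registers at this amine nitrogen in a ring. Going by these compounds alone, the new information lies in the pair of dichlorophenyl isomers, where 2,5-dichlorophenyl in place of 2,3-dichlorophenyl gives a number 1 percentage points higher from compound 1 to compound 4 (within the scatter), showing that the two chlorine patterns cannot be told apart here and extending the flat picture to all four aryl groups, with no compound going against it. No supporting data bear on why this position gives so little response in any of the four compounds.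

The compounds shown leave open whether this nitrogen would respond to a group other than a substituted phenyl, such as a benzyl group, a pyridine ring or an aryl ring carrying a carboxylic acid or an amine. They also leave open whether a change elsewhere on the shared core, such as replacing the 4-chlorophenyl on the carbonyl, would move the read-out at all.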